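The compounds below may be only part of what the source reports. "The series", "measured", "known", "first", "only" and "open" are said of these compounds alone.

Compound 2 `Cc1cc(SC(C)C)c(S(C)(=O)=O)cc1C(=O)N=C(N)N` stands, in a functional assay for inhibition of sodium/hydrogen exchanger (Oryctolagus cuniculus) (on this read-out higher numbers stand for weaker inhibition and lower numbers for stronger inhibition), at 12 nM. Going by the values given here, compound 1 `Cc1cc(-c2ccco2)c(S(C)(=O)=O)cc1C(=O)N=C(N)N` gives 16 nM in this assay, and the only measured step, a 1.3-fold lower number from compound 1 to compound 2 (0.12 log units; within the scatter), lies within the scatter, so the two numbers cannot be ordered. Compound 3 `Cc1cc(Sc2ccc(Cl)cc2)c(S(C)(=O)=O)cc1C(=O)N=C(N)N` has not been measured; it differs from compound 2 by 4-chlorophenyl in place of isopropyl on a sulfur. Among the compounds with values here, the one measured step concerns a different change, a furan-2-yl on an aromatic carbon giving way to isopropylsulfanyl, and it left the number within the scatter; no measured step exchanges groups on the sulfur itself. Because a 1.3-fold lower number from compound 1 to compound 2 (0.12 log units; within the scatter) lay within the scatter, compound 3 is expected to show a 1.3-fold higher number from compound 2 to compound 3 (0.10 log units; within the scatter), with no clear direction beyond the scatter. Compound 3 is therefore estimated at 15 nM, in a range from 5 nM to 50 nM.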

Compound 3, half-maximal inhibitory concentration: 19 nM
Compound 3: middle estimate off by 1.3-fold (0.10 log units), on the low side; measured number inside the range.
By their numbers in this assay, from the lowest: compounds 2, 1 and 3 (each within the scatter of the next).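

Going by these compounds alone, with 4-chlorophenyl in place of isopropyl on the sulfur, the first exchange on the sulfur itself gives a 1.6-fold higher number from compound 2 to compound 3 (0.20 log units; within the scatter) in this assay, so a six-membered aromatic ring carrying chlorine leaves the number within the scatter. Replacing furan-2-yl on the aromatic carbon with (4-chlorophenyl)sulfanyl gives a 1.2-fold higher number from compound 1 to compound 3 (0.07 log units; within the scatter), so furan-2-yl, isopropylsulfanyl and (4-chlorophenyl)sulfanyl cannot be ordered at this position on this read-out. No accompanying evidence bears on this result.

As far as these compounds go, it remains open whether an amine, a carboxylic acid or a longer chain on the sulfur would move the number beyond the scatter. The compounds shown also do not separate any contribution of the chlorine from that of the ring, as a plain phenyl on the sulfur is not among them.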